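This account rests on a few compounds, and the source may have more. Where it says the series, first, only, none or still open, it means among the compounds named here.

Working notes on the series. Compound 1 `CC(=NNC(=S)Nc1ccc(I)cc1)c1ccccn1` gives 59 nM in a functional assay on U-87MG ATCC cells (Homo sapiens) for cytotoxicity, read by MTT assay, with a stated time of 48 h (on this read-out lower numbers stand for stronger inhibition and higher numbers for weaker inhibition), the highest of the three numbers recorded there. Compound 2 `C/C(=N\NC(=S)Nc1ccccc1[N+](=O)[O-])c1ccccn1` gives 4.3 nM in this assay, and compound 3 `CC(=NNC(S)=Nc1ccccc1Cl)c1ccccn1` gives 2.6 nM; against both, compound 1 stands far higher, and in each case the gap is beyond the scatter. Among the measured compounds shown here, no step between measured compounds that differ in one place is available, so the shift from compound 1 to compound 4 `CC(=NNC(=S)Nc1ccc(F)cc1)c1ccccn1` has no direct precedent in the set.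

The change itself: fluoro in place of iodo on an aromatic carbon. Only the substituent on the aromatic carbon changes; the shared core is untouched. Nothing in the measured compounds speaks to a halogen swap at this position, so the expectation rests on the premise that a small change of this kind stays modest. The expected step from compound 1 to compound 4 is a 1.4-fold higher number from compound 1 to compound 4 (0.16 log units; within the scatter), tending toward a higher number, near the edge of the scatter. For compound 4 the estimate in this assay is 85 nM, with a range from 25 nM to 280 nM.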

Compound 4, half-maximal inhibitory concentration: 10 nM
The estimate for compound 4 lay 8.5-fold (0.93 log units) above the measured number, and the stated range ends above it.
By their numbers in this assay, from the lowest: compounds 3 and 2 (each within the scatter of the next); then compound 4; then compound 1.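

Fluoro in place of iodo on an aromatic carbon, para to a large group, gives a 5.9-fold lower number from compound 1 to compound 4 (0.77 log units; beyond the scatter) in this assay. Among the compounds shown here, this is the only step that isolates one place, and it shows that the number responds to the halogen at this position, even though one heavy atom replaces one heavy atom and the counts of rings, hydrogen-bond donors, hydrogen-bond acceptors and net charge stay the same. No available measurement bears on the reason for this step.

On these data alone, it remains open how bromo, a methoxy group or an amine on this same aromatic carbon would read against iodo and fluoro. Also open, as far as these compounds go, is whether the same halogen swap would give a step of similar size on another core.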